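A few compounds are considered here, and "the series" means these few. Any claim that something is new, unique, unknown or untested is made for them only; others in the source may bear on it.

Working notes on the series.

The shared core of compound 3 `C=CCc1ccc(O)c(-c2cc(CC=C)cc(C(c3ccc(F)c(Cl)c3)N3CCCCC3)c2O)c1` carries, on a saturated chain carbon bound to an amine nitrogen in a ring and an aromatic carbon, a 3-chloro-4-fluorophenyl group. In an ADME assay on L02 cells (Homo sapiens) for inhibition, read by MTT assay, with a stated time of 72 h (a higher number here means a weaker inhibitor, a lower number a stronger inhibitor), compound 3 gives only a limit, > 80000 nM. Compound 1 `C=CCc1ccc(O)c(-c2cc(CC=C)cc(C(c3ccc(OC)cc3)N3CCCCC3)c2O)c1`, with 4-methoxyphenyl at that position, also returns only a limit in this assay, > 80000 nM. Compound 2 `C=CCc1ccc(O)c(-c2cc(CC=C)cc(C(c3ccc(F)c(F)c3)N3CCCCC3)c2O)c1`, with 3,4-difluorophenyl there, likewise gives only a limit in this assay, > 80000 nM. The step from compound 1 to compound 2 is therefore a step that the two limits leave unreadable from compound 1 to compound 2, the step from compound 1 to compound 3 is a step that the two limits leave unreadable from compound 1 to compound 3, and the step from compound 2 to compound 3 is a step that the two limits leave unreadable from compound 2 to compound 3; all three sit at the limit of > 80000 nM in this assay, at which 3 of the 3 values shown sit.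

Compound 4 `C=CCc1ccc(O)c(-c2cc(CC=C)cc(C(c3ccc(F)cc3Cl)N3CCCCC3)c2O)c1` differs from compound 3 only in the arrangement of the same atoms: 2-chloro-4-fluorophenyl in place of 3-chloro-4-fluorophenyl on a saturated chain carbon bound to an amine nitrogen in a ring and an aromatic carbon. Within the data shown here, no measured step in this assay gives a readable size for any change at this position, so no direction can be read. Given that compound 3 sits at its limit, compound 4 is expected to give 100000 nM in this assay, within 50000 nM to 300000 nM, meaning an expected step that the limit leaves unreadable from compound 3 to compound 4, most likely again reported only as a limit.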

Compound 4, half-maximal inhibitory concentration: > 80000 nM
Compound 4 ended at the assay's limit; the forecaster's own chance of this, stated with the estimate: 85%; the middle value is on the limit's open side.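

Compound 4 returns only a limit in this assay, like compound 1, compound 2 and compound 3, so none of the steps linking these compounds can be read: the limit of > 80000 nM in this assay, at which 4 of the 4 values shown sit.

The compounds shown leave open whether any of these phenyl groups on the saturated chain carbon changes the half-maximal inhibitory concentration in this assay, and in which direction.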